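A few compounds are considered here, and "the series" means these few. Any claim that something is new, unique, unknown or untested is made for them only; others in the source may bear on it.

In a functional assay on B16 cells (Mus musculus) for inhibition (on this read-out lower numbers stand for stronger inhibition and higher numbers for weaker inhibition), compound 1 `O=C(CN(Cc1ccccc1)NC(=O)CBr)NNC(=O)OCc1ccccc1` gives 1500 nM and compound 2 `CC(C)CN(CC(=O)NN(Cc1ccccc1)c1cnccn1)NC(=O)CBr` gives 14800 nM. Compound 2 therefore holds the higher of the two numbers, and the gap between them lies beyond the scatter. The unmeasured compound 3 `CC(C)CN(CC(=O)NN(Cc1ccccc1)c1cnccn1)NC(=O)Cc1cccc(Br)c1` differs from compound 2 in one place: 3-bromophenyl in place of bromo on a saturated chain carbon bound to a carbonyl carbon. In words, this puts 3-bromophenyl in place of bromo on a saturated chain carbon bound to a carbonyl carbon. Within the data shown here, no step between measured compounds covers this kind of replacement, so the data give no direct guide to its size. In this assay, a modest weakening is expected, starting from compound 2 at 14800 nM, and it may not clear the scatter. The estimated change is a 1.4-fold higher number from compound 2 to compound 3 (0.13 log units; within the scatter). The expected value for compound 3 is 20000 nM, with an estimated range from 5000 nM to 80000 nM.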

Compound 3, half-maximal inhibitory concentration: 33300 nM
Compound 3: middle estimate off by 1.7-fold (0.22 log units), on the low side; the measured number falls inside the stated range.
By their numbers in this assay, from the lowest: compound 1; then compound 2; then compound 3.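

In this assay, 3-bromophenyl in place of bromo on a saturated chain carbon bound to a carbonyl carbon gives a 2.3-fold higher number from compound 2 to compound 3 (0.35 log units; beyond the scatter) as a modest step beyond the scatter. Among these compounds, this is the first reading at this position, and it shows that the larger group, with its six-membered aromatic ring, weakens inhibition only modestly here, while compound 3 still gives a measurable half-maximal value. No available evidence accounts for the size of this step.

As far as these compounds go, whether the step comes from the ring or from its bromine remains open, and plain phenyl or methyl in place of bromo would help to separate the two. Compound 1 differs from compound 2 in more than one place, so it does not settle this question.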